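The source may report more compounds than this note shows. Statements on the series, on what has been measured and on what is new or still open speak of the compounds shown alone.

Of the compounds shown here, three have been read so far in a functional assay on the whole organism for agonist activity, with Mus musculus as the target; on this read-out lower numbers stand for an effect already at smaller amounts and higher numbers for an effect only at larger amounts of compound. Compound 1 (`CCc1nccn1CC#CCN1CCCC1=O`) gives > 100 mg/kg, which is a limit and not a number. Compound 2 (`CC1CCC(=O)N1CC#CCn1ccnc1`) gives > 100 mg/kg, again a limit. Compound 3 (`CC(=O)NCC#CCn1ccnc1`) gives > 100 mg/kg, likewise a limit. Compound 3 therefore has no numerical place in the series, and it stands with the other two: the limit of > 100 mg/kg in this assay, at which 3 of the 3 values shown sit.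

Compound 4 (`CC(=O)NCC#CCn1cncc1C`) differs from compound 3 in one place: methyl in place of hydrogen on an aromatic carbon. A methyl takes the place of a hydrogen on an aromatic carbon, and the rest of the structure stays the same. For the measured compounds named here, no measured pair shows what this change does in this assay, so any expectation remains weakly supported. The expectation rests on compound 3, whose reading of > 100 mg/kg is a limit. The expected change, a number no higher from compound 3 to compound 4 (the limit leaves the size open), is no shift in either direction beyond the usual scatter, and another reading at the limit is the likeliest outcome. For compound 4 the estimated value is 100 mg/kg, with an expected range of 40 mg/kg to 250 mg/kg.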

Compound 4, dose for half-maximal effect: > 100 mg/kg
Compound 4: only a limit was reported; the forecaster's own chance of this, stated with the estimate: 75%; the middle value sits exactly at the limit.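

For the compounds shown here, compound 3 and compound 4 both read as limits and not numbers, so no step between them can be read in this assay and the effect of methyl in place of hydrogen on an aromatic carbon stays hidden: the limit of > 100 mg/kg in this assay, at which 4 of the 4 values shown sit. The compounds shown leave open which structural change, if any, would bring a numerical value on this read-out.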